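Iodo in Place of Ethynyl on a Nucleoside Core

A few compounds are considered here, and "the series" means these few. Any claim that something is new, unique, unknown or untested is made for them only; others in the source may bear on it.

Measured compounds in a functional assay on K562 cells (Homo sapiens), read by MTT assay, with a stated time of 72 h; a higher number here means a weaker inhibitor, a lower number a stronger inhibitor:
compound 1, `C#Cc1cn([C@@H]2O[C@H](CO)[C@@H](O)[C@H]2O)c2ncnc(NC)c12`: > 20000 nM.
compound 2, `C#Cc1cn([C@@H]2O[C@H](CO)[C@@H](O)[C@H]2O)c2nc(C)nc(N)c12`: > 20000 nM.
compound 3, `Cc1nc(N)c2c(I)cn([C@@H]3O[C@H](CO)[C@@H](O)[C@H]3O)c2n1`: 5120 nM.

The assay gives compound 1 only a limit, > 20000 nM. For compound 2 the assay likewise reports only a limit, > 20000 nM. Compound 3 gives a number, 5120 nM. Two of the three values sit at the limit of > 20000 nM in this assay, at which 2 of the 3 values shown sit, so the measured picture is thin. Compound 2 and compound 3 differ in one place, (iodo in place of ethynyl on an aromatic carbon), and that change made an at least 3.9-fold lower number from compound 2 to compound 3 (0.59 log units; beyond the scatter). Compound 1 and compound 2 are built from the same atoms joined differently; the difference between the two cores is not broken down here.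

Compound 4, `CNc1ncnc2c1c(I)cn2[C@@H]1O[C@H](CO)[C@@H](O)[C@H]1O`, has not yet been measured. It differs from compound 1 by iodo in place of ethynyl on an aromatic carbon, the same change as from compound 2 to compound 3, made on the same kind of place. Compound 4 is expected to give a step of an at least 3.3-fold lower number from compound 1 to compound 4 (0.52 log units; beyond the scatter) from compound 1, an expectation resting on an at least 3.9-fold lower number from compound 2 to compound 3 (0.59 log units; beyond the scatter) and nothing more. Compound 4 is therefore estimated at 6000 nM, with a range from 2000 nM to 20000 nM.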

Compound 4, half-maximal inhibitory concentration: > 100000 nM
Compound 4: a limit, no number (the forecaster's own chance of this, stated with the estimate: 35%); middle value at least 16-fold (1.22 log units) away from the limit.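

In this assay compound 1 and compound 4 are both reported only as limits, so the step between them cannot be read. The compounds shown leave open whether iodo in place of ethynyl on an aromatic carbon changes the number at all on the core of compound 1, as it did on the core of compound 2.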